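Solubility in the fused core series: piperidinyl to pyridinyl

This account rests on a few compounds, and the source may have more. Where it says the series, first, only, none or still open, it means among the compounds named here.

Among the compounds with values here, compound 1 `CC(C)CN1C(=O)c2ccccc2[C@H](C(=O)Nc2ccc(F)c(C#N)c2)[C@H]1C1CCCNC1` gives 54000 nM in a physicochemical assay for solubility, in phosphate buffer, with a stated time of 18 h, at pH 7 (on this read-out lower numbers stand for lower solubility and higher numbers for higher solubility), the highest of the two numbers measured so far. Compound 2 `CC(C)CN1C(=O)c2ccccc2[C@H](C(=O)Nc2ccc(F)c(C#N)c2)[C@H]1c1ccoc1` gives 15000 nM in this assay. Within the data shown here, the one step between measured compounds is a 3.6-fold lower number from compound 1 to compound 2 (0.56 log units; beyond the scatter).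

Compound 3 `CC(C)CN1C(=O)c2ccccc2[C@H](C(=O)Nc2ccc(F)c(C#N)c2)[C@H]1c1cccnc1` differs from compound 1 by pyridin-3-yl in place of piperidin-3-yl on a saturated ring carbon. Among the measured compounds shown here, this change has no exact measured counterpart; the step from compound 1 to compound 2, which swaps the same group for furan-3-yl, bears on it most closely, and that step lowered solubility modestly, beyond the scatter. Pyridin-3-yl keeps the acceptor count of piperidin-3-yl but loses its donor and is aromatic, so a drop in this assay of similar size is expected, with the estimated step being a 3.0-fold lower number from compound 1 to compound 3 (0.48 log units; beyond the scatter). Compound 3 is therefore expected to give 18000 nM in this assay, within a range of 6000 nM to 54000 nM.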

Compound 3, solubility: 55000 nM
The estimate for compound 3 lay 3.1-fold (0.49 log units) below the measured number, outside the stated range (above it).
By their numbers in this assay, from the lowest: compound 2; then compounds 1 and 3 (each within the scatter of the next).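

In this assay, pyridin-3-yl in place of piperidin-3-yl on this saturated ring carbon gives a 1.0-fold higher number from compound 1 to compound 3 (0.01 log units; within the scatter), so the aromatic ring without a hydrogen-bond donor and the non-aromatic ring with one cannot be told apart on this read-out. Aromaticity alone therefore does not sort these numbers: between two aromatic rings, pyridin-3-yl in place of furan-3-yl gives a 3.7-fold higher number from compound 2 to compound 3 (0.56 log units; beyond the scatter), and compound 2 stands apart from both six-membered rings. No data shown here explain why the numbers fall this way.

On these data alone, it remains open whether a plain phenyl ring at this carbon, with no ring nitrogen, would read with compound 2 or with compounds 1 and 3. As far as these compounds go, an open-chain amine in the same place is equally open.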